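Para-bromo on the pyrazoline aryl: expectation for compound 4

A few compounds are considered here, and "the series" means these few. Any claim that something is new, unique, unknown or untested is made for them only; others in the source may bear on it.

Measured so far in a functional assay on BGC-823 cells (Homo sapiens) for inhibition, read by CCK-8 assay, with a stated time of 48 h; on this read-out lower numbers stand for stronger inhibition and higher numbers for weaker inhibition:
compound 1 `c1ccc(C2=NN(C3=NC(c4ccccc4)CS3)C(c3cccc4ccccc34)C2)cc1` gives 14300 nM
compound 2 `Cc1ccc(C2=NN(C3=NC(c4ccccc4)CS3)C(c3ccc4ccccc4c3)C2)cc1` gives 8940 nM
compound 3 `c1ccc(C2=NN(C3=NC(c4ccccc4)CS3)C(c3ccc4ccccc4c3)C2)cc1` gives 9620 nM

Compound 1 has the highest number of the three, yet its nearest neighbour compound 3 and its furthest neighbour compound 2 both sit within the scatter of it, so no ordering among the three can be claimed.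

Compound 4 `Brc1ccc(C2=NN(C3=NC(c4ccccc4)CS3)C(c3cccc4ccccc34)C2)cc1` differs from compound 1 by bromo in place of hydrogen on an aromatic carbon.

Neither measured step addresses a bromo substituent. The step of a 1.5-fold lower number from compound 1 to compound 3 (0.17 log units; within the scatter) moves the naphthyl attachment point and stays within the scatter. Among the compounds with values here, the step of a 1.1-fold higher number from compound 2 to compound 3 (0.03 log units; within the scatter) removes a methyl from the same phenyl that carries the bromo in compound 4 and is also within the scatter; this is the only step that bears on the same aromatic position, and it shows a para substituent there leaving the number essentially unchanged. On this basis no step beyond the scatter is expected in this assay for compound 4, and the estimated step is a 1.2-fold lower number from compound 1 to compound 4 (0.08 log units; within the scatter).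

Compound 4 is therefore estimated at 12000 nM, with a range from 5000 nM to 30000 nM.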

Compound 4, half-maximal inhibitory concentration: 17400 nM
Compound 4: middle estimate off by 1.5-fold (0.16 log units), on the low side; the range from low to high includes it.
By their numbers in this assay, from the lowest: compounds 2, 3, 1 and 4 (each within the scatter of the next).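

In this assay the change from phenyl to 4-bromophenyl on the core of compound 1 gives a 1.2-fold higher number from compound 1 to compound 4 (0.09 log units; within the scatter) and no readable shift for a bromine on this aromatic carbon, para to a large group. Earlier, the only substituent seen on this ring was the methyl of compound 2, and that with the naphthalen-2-yl group; the bromo now gives the same reading with the naphthalen-1-yl group, so two different groups at this place have left the number within the scatter. Nothing at hand offers an explanation for this result.

Open, going by these compounds, is whether any group on this phenyl moves the number beyond the scatter; an amine or a carboxylic acid here would test that. Also open, on these data alone, is how the bromo reads with the naphthalen-2-yl group of compound 3.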